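The source may hold more compounds than are shown below. What is called first, only, known or untested is meant among the compounds shown, and "the series" means these compounds.

Among the compounds with values here, in an assay on isolated protein for inhibition of tyrosine-protein kinase receptor UFO (Homo sapiens), read by FRET and Z'-LYTE, with a stated time of 1.5 h (a higher number here means a weaker inhibitor, a lower number a stronger inhibitor), compound 2 `CCc1ccc2c(c1)c(=O)c(C(=O)Nc1ccc(Oc3ncnc4[nH]cc(-c5ccccc5)c34)c(F)c1)c(C)n2C` gives 6 nM, the lowest of the three numbers measured so far. Compound 1 `Cc1ccc2c(c1)c(=O)c(C(=O)Nc1ccc(Oc3ncnc4[nH]cc(-c5ccccc5)c34)c(F)c1)c(C)n2C` gives 100 nM, and compound 3 `CCc1ccc2c(c1)c(=O)c(C(=O)Nc1ccc(Oc3ncnc4[nH]cc(-c5ccccc5)c34)c(C)c1)c(C)n2C` gives 1120 nM. Compound 4 `Cc1c(C(=O)Nc2ccc(Oc3ncnc4[nH]cc(-c5ccccc5)c34)c(F)c2)c(=O)c2cc(C3=CCCC3)ccc2n1C` differs from compound 2 by cyclopent-1-en-1-yl in place of ethyl on an aromatic carbon. Within the data shown here, only one measured step touches the same place on the shared core: a 17-fold lower number from compound 1 to compound 2 (1.22 log units; beyond the scatter). The other step, a 190-fold higher number from compound 2 to compound 3 (2.27 log units; beyond the scatter), concerns a different ring and does not bear on this change. Among the measured compounds shown here, no compound with a larger group at this place has been measured, so the direction is uncertain; a modest step in either direction is expected, a 1.7-fold higher number from compound 2 to compound 4 (0.22 log units; within the scatter). Compound 4 is therefore estimated at 10 nM, with a range from 2 nM to 60 nM.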

Compound 4, half-maximal inhibitory concentration: 3320 nM
The estimate for compound 4 lay 330-fold (2.52 log units) below the measured number, and the stated range ends below it.
By their numbers in this assay, from the lowest: compound 2; then compound 1; then compound 3; then compound 4.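

Adding one carbon at this place helped, but the gain does not carry on to a larger group. Cyclopent-1-en-1-yl in place of ethyl gives a 550-fold higher number from compound 2 to compound 4 (2.74 log units; beyond the scatter) and, in place of methyl, gives a 33-fold higher number from compound 1 to compound 4 (1.52 log units; beyond the scatter) so this ring does worse here than either small chain. Nothing measured here explains the drop.

The compounds shown leave open whether the ring, its double bond or simply the larger number of carbons matters most. A saturated cyclopentyl ring, a propyl chain or a methoxy group at this place could help separate these possibilities.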